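Replacing trifluoromethyl with hydrogen on the shared core

This account rests on a few compounds, and the source may have more. Where it says the series, first, only, none or still open, it means among the compounds named here.

Both values below come from an ADME assay on MDCK cells (Canis lupus familiaris) for cytotoxicity (on this read-out lower numbers stand for higher toxicity in this test and higher numbers for lower toxicity in this test), as the single read-out:

- Compound 1 `O=[N+]([O-])C1=NNc2nc(C(F)(F)F)nn2C1c1ccc(O)c(O)c1` at 183000 nM
- Compound 2 `O=[N+]([O-])C1=NNc2nc(C(F)(F)F)nn2C1c1ccc(O)cc1O` at 108000 nM

Compound 2 at 108000 nM lies within the scatter of compound 1 at 183000 nM on these two numbers, so no order can be drawn between them. Still unmeasured is compound 3 `O=[N+]([O-])C1=NNc2ncnn2C1c1ccc(O)cc1O` which differs from compound 2 by one change hydrogen in place of trifluoromethyl on an aromatic carbon in words hydrogen in place of trifluoromethyl on an aromatic carbon, between two ring nitrogen atoms.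

Within the data shown here, the only measured step of a 1.7-fold lower number from compound 1 to compound 2 (0.23 log units; within the scatter) is 2,4-dihydroxyphenyl in place of 3,4-dihydroxyphenyl on a saturated ring carbon, so it does not touch the carbon changing here. Among the measured compounds shown here, both measured compounds carry trifluoromethyl, and no measured pair shows its removal. The data therefore give no direction, and no step beyond the scatter is expected in this assay from this change. The expected step is a 1.1-fold higher number from compound 2 to compound 3 (0.05 log units; within the scatter) and it stays a loose estimate. For compound 3 the estimated value is 120000 nM with an expected range from 50000 nM to 300000 nM as a working figure.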

Compound 3, half-maximal cytotoxic concentration: 90000 nM
Estimate against measurement, compound 3: 1.3-fold (0.12 log units) above; the range from low to high includes it.
By their numbers in this assay, from the lowest: compounds 3, 2 and 1 (each within the scatter of the next, the first and the last beyond it).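

Notes on the carbon that carries trifluoromethyl: in this assay, the exchange of trifluoromethyl for hydrogen on this aromatic carbon, between two ring nitrogen atoms, gives a 1.2-fold lower number from compound 2 to compound 3 (0.08 log units; within the scatter) and is the first measured pair to touch this position. On the 2,4-dihydroxyphenyl compounds, the four heavy atoms of trifluoromethyl can therefore leave this carbon with no step beyond the scatter in this assay, so the group is not required to keep the read-out where it stands in this pair. This single pair gives no order between the two compounds, and no measurement offered here bears on why the read-out holds across the change.

Among these compounds, whether the same exchange reads the same way with the 3,4-dihydroxyphenyl of compound 1 remains open, since this pair covers only one aryl group. Also open, from the compounds shown here alone, is how a methyl, an amine or a carboxylic acid on this carbon would stand against hydrogen and trifluoromethyl, including whether any group at this position can move the number beyond the scatter.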